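The source may report more compounds than this note shows. Statements on the series, on what has been measured and on what is new or still open speak of the compounds shown alone.

In an ADME assay on MRC5 cells (Homo sapiens), read by MTT assay, with a stated time of 3 days (on this read-out higher numbers stand for weaker inhibition and lower numbers for stronger inhibition), compound 1, `CN(C)c1ncnc2[nH]cc(Sc3cccs3)c12`, gives > 150000 nM, which is a limit and not a number, so its standing rests on (the limit of > 150000 nM in this assay, at which 1 of the 3 values shown sits). Compound 2, `CNc1ncnc2[nH]cc(Sc3cccs3)c12`, reads 148000 nM, and compound 3, `c1csc(Sc2c[nH]c3ncnc(-c4cccs4)c23)c1`, reads 54500 nM.

The step to follow leads to compound 4, `COc1ncnc2[nH]cc(Sc3cccs3)c12`, and its change is methoxy in place of dimethylamino on an aromatic carbon. Among the measured compounds shown here, three measured steps bear on it. Hydrogen in place of methyl on a nitrogen gives an at least 1.0-fold lower number from compound 1 to compound 2 (0.00 log units; that floor lies within the scatter). Thiophen-2-yl in place of dimethylamino gives an at least 2.7-fold lower number from compound 1 to compound 3 (0.43 log units; beyond the scatter), and thiophen-2-yl in place of methylamino gives a 2.7-fold lower number from compound 2 to compound 3 (0.43 log units; beyond the scatter). For the measured compounds named here, replacing the amino group at this carbon has therefore moved the number only modestly, and no measured compound carries methoxy there. A small move toward lower numbers is expected, perhaps none beyond the scatter. The estimated result is an at least 1.5-fold lower number from compound 1 to compound 4 (0.17 log units; that floor lies within the scatter). For compound 4 the expected value is 100000 nM, with an estimated range from 45000 nM to 170000 nM.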

Compound 4, half-maximal inhibitory concentration: 148000 nM
Beside the measured number, compound 4's estimate is 1.5-fold (0.17 log units) below it; the range from low to high includes it.
By their numbers in this assay, from the lowest: compound 3; then compounds 2 and 4 (each within the scatter of the next). At a limit, above all of these: compound 1.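

In this assay, methoxy and methylamino on this aromatic carbon cannot be told apart, with no change at the digits printed from compound 2 to compound 4 (within the scatter), so exchanging one small group for the other leaves the number where it was. Among these compounds, only thiophen-2-yl gives a number clearly set apart at this carbon, and going back to a small group gives a 2.7-fold higher number from compound 3 to compound 4 (0.43 log units; beyond the scatter). Compound 1 stands only at a limit, so an at least 1.0-fold lower number from compound 1 to compound 4 (0.00 log units; that floor lies within the scatter) is a floor and does not show how dimethylamino truly compares with methoxy: the limit of > 150000 nM in this assay, at which 1 of the 4 values shown sits.

Still open, as far as these compounds go, is whether another ring at this carbon, such as phenyl, would also lower the number, or whether a longer chain, such as ethoxy, would read like methoxy. From the compounds shown here alone, what a change elsewhere on the shared core would do also remains unknown.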